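The compounds below may be only part of what the source reports. "The series", "measured", "known", "first", "only" and "open" are said of these compounds alone.

Measured compounds:
compound 1 `CCNc1nc(N)c2nc(O)n(Cc3ccccc3)c2n1`, giving 1 uM.
compound 2 `Cc1ccc(Cn2c(O)nc3c(N)ncnc32)cc1`, giving 10 uM.
compound 3 `Nc1ncnc2c1nc(I)n2Cc1ccccc1`, giving > 10 uM, which is a limit of the assay and not a number.

All three were tested in a functional assay (spleen, spleen) for activation, with Mus musculus as the target; on this read-out lower numbers stand for an effect already at smaller amounts and higher numbers for an effect only at larger amounts of compound. Of the two numbers shown, compound 1 stands at the lowest; the nearest, compound 2, sits a step higher that lies beyond the usual scatter. Compound 3 gives only a limit, (the limit of > 10 uM in this assay, at which 1 of the 3 values shown sits).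

Compound 4 `CNc1nc(N)c2nc(O)n(Cc3ccccc3)c2n1` has not yet been measured in this assay. It differs from compound 1 in one place: hydrogen in place of methyl on a saturated chain carbon bound to a nitrogen on an aromatic ring. Within the data shown here, no measured pair shows this change, so its size cannot be read from the numbers here. The step is expected to be small: a 1.5-fold higher number from compound 1 to compound 4 (0.18 log units; within the scatter), within the usual scatter, in either direction or none at all. Compound 4 is estimated at 1.5 uM, with a range from 0.5 uM to 5 uM.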

Compound 4, minimum effective concentration: 1 uM
Beside the measured number, compound 4's estimate is 1.5-fold (0.18 log units) above it, and the stated range covers the measured number.
By their numbers in this assay, from the lowest: compounds 1 and 4 (each within the scatter of the next); then compound 2.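

In this assay, cutting the chain on the ring nitrogen from ethylamino to methylamino gives no change at the digits printed from compound 1 to compound 4 (within the scatter), the first step read at this place. On this read-out, compound 1 and compound 4 cannot be told apart, so the ethyl group of compound 1 can give way to methyl without a visible difference. Nothing in the data shown offers a reason for this result.

From the compounds shown here alone, what a longer chain such as propyl or butyl would do at this nitrogen stays open, as does the effect of a plain amino group or a cyclic amine such as pyrrolidine in place of the methylamino group. Going by these compounds, it is also open whether the same exchange would read alike on a core carrying other groups, since this single pair is all that speaks to this place.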